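Para-substituent swap on the aryl iminosugar core

The source may report more compounds than this note shows. Statements on the series, on what has been measured and on what is new or still open speak of the compounds shown alone.

Measured so far:
- Compound 1 `OC[C@@]1(c2ccc(F)cc2)NC[C@@H](O)[C@@H]1O`: 12000 nM
- Compound 2 `Cc1ccc([C@]2(CO)NC[C@@H](O)[C@@H]2O)cc1`: 43000 nM
- Compound 3 `OC[C@]1(c2cccc(F)c2)NC[C@H](O)[C@H]1O`: 43000 nM

In an assay on isolated protein for inhibition of lysosomal alpha-glucosidase (Rattus norvegicus), read by colorimetric assay (a higher number here means a weaker inhibitor, a lower number a stronger inhibitor), compound 2 stands level with compound 3 at the digits shown, within the scatter; the only other number, that of compound 1, is lower, by the step of a 3.6-fold higher number from compound 1 to compound 2 (0.55 log units; beyond the scatter).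

Compound 4 `COc1ccc([C@]2(CO)NC[C@@H](O)[C@@H]2O)cc1` differs from compound 2 by methoxy in place of methyl on an aromatic carbon. Going by the values given here, no measured step moves between methoxy and methyl; the one step that bears on this position, a 3.6-fold higher number from compound 1 to compound 2 (0.55 log units; beyond the scatter), was modest. A step of similar size or none beyond the scatter is expected in this assay, with the number more likely drifting higher than lower.

For compound 4 the estimate is 50000 nM, with a range of 15000 nM to 150000 nM, an expected step of a 1.2-fold higher number from compound 2 to compound 4 (0.07 log units; within the scatter).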

Compound 4, half-maximal inhibitory concentration: 395000 nM
For compound 4 the middle estimate is 7.9-fold (0.90 log units) below the measured one; the whole stated range lies below it.
By their numbers in this assay, from the lowest: compound 1; then compounds 2 and 3 (each within the scatter of the next); then compound 4.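

In this assay, going by these compounds alone, the aromatic carbon carrying the substituent tolerates methoxy far less well than the earlier compounds could show: methoxy in place of methyl gives a 9.2-fold higher number from compound 2 to compound 4 (0.96 log units; beyond the scatter) and methoxy in place of fluoro gives a 33-fold higher number from compound 1 to compound 4 (1.52 log units; beyond the scatter) across this position. Among compounds 1, 2 and 4 the number rises from fluoro through methyl to methoxy, so this position clearly separates the three groups. Nothing available explains the sharp loss with methoxy.

Still open, on these data alone, is whether a larger ether such as ethoxy weakens inhibition further at this position. An amine or a carboxylic acid there also remains untested in the compounds shown.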